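The source may report more compounds than this note shows. Statements on the series, on what has been measured and on what is new or still open speak of the compounds shown alone.

Series notes. Among the measured compounds shown here, compound 3 `CN(Cc1ccccc1)CC1CCN(CCCc2c[nH]c3ccc(-n4cnnc4)cc23)CC1` gives the lowest number of the three so far measured in an assay on CHO cells for displacement of a labelled ligand from 5-hydroxytryptamine receptor 1D (Homo sapiens) (a higher number here means a weaker inhibitor, a lower number a stronger inhibitor), at 0.9 nM. Compound 1 `CN(Cc1cccs1)C1CCN(CCCc2c[nH]c3ccc(-n4cnnc4)cc23)CC1` gives 4.3 nM and compound 2 `c1ccc2c(c1)CCC2NC1CCN(CCCc2c[nH]c3ccc(-n4cnnc4)cc23)CC1` gives 8.9 nM; the steps of a 4.8-fold lower number from compound 1 to compound 3 (0.68 log units; beyond the scatter) and a 9.9-fold lower number from compound 2 to compound 3 (1.00 log units; beyond the scatter) are both beyond the scatter, as is a 2.1-fold higher number from compound 1 to compound 2 (0.32 log units; beyond the scatter). Compound 4 `CN(Cc1ccco1)C1CCN(CCCc2c[nH]c3ccc(-n4cnnc4)cc23)CC1` is not yet measured; it carries ((furan-2-yl)methyl)(methyl)amino in place of (benzyl(methyl)amino)methyl on a saturated ring carbon. The step of a 4.8-fold lower number from compound 1 to compound 3 (0.68 log units; beyond the scatter) bears on it most closely, because compound 1 gives 4.3 nM with the amino group attached to the saturated ring carbon itself and a five-membered aromatic ring on its far side, as in compound 4. Roughly the reverse of that step is therefore expected, and compound 4 is expected to show a 5.0-fold higher number from compound 3 to compound 4 (0.70 log units; beyond the scatter) in this assay. The estimate for compound 4 is 4.5 nM, with a range of 1.5 nM to 14 nM.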

Compound 4, half-maximal inhibitory concentration: 9.3 nM
For compound 4 the middle estimate is 2.1-fold (0.32 log units) below the measured one; measured number inside the range.
By their numbers in this assay, from the lowest: compound 3; then compound 1; then compounds 2 and 4 (each within the scatter of the next).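

In this assay, among the compounds shown here, furan-2-yl in place of thiophen-2-yl is the one step here that changes only the five-membered aromatic ring (a 2.2-fold higher number from compound 1 to compound 4 (0.34 log units; beyond the scatter)). ((furan-2-yl)methyl)(methyl)amino in place of (benzyl(methyl)amino)methyl gives a larger step (a 10-fold higher number from compound 3 to compound 4 (1.01 log units; beyond the scatter)), but it changes the aromatic ring and the attachment to the saturated ring carbon together, so these two changes cannot be separated. Compared with (2,3-dihydro-1H-inden-1-yl)amino, the group shows no difference beyond the scatter (a 1.0-fold higher number from compound 2 to compound 4 (0.02 log units; within the scatter)). Nothing available explains these differences. Still open, on these data alone, is how ((furan-2-yl)methyl)(methyl)aminomethyl, which would separate the ring change from the attachment change, would read in this assay.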